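Heteroaryl swap on the amine nitrogen: bicyclic group

A few compounds are considered here, and "the series" means these few. Any claim that something is new, unique, unknown or untested is made for them only; others in the source may bear on it.

Values in a functional assay on LNCaP cells (Homo sapiens) for antiproliferative activity, read by CCK-8 assay, with a stated time of 6 days; on this read-out lower numbers stand for stronger inhibition and higher numbers for weaker inhibition:
compound 1 `C[C@@H](Cn1ccc(-c2ccc(C#N)c(Cl)c2)n1)Nc1ccccn1`: 1110 nM
compound 2 `Cc1ccnc(N[C@@H](C)Cn2ccc(-c3ccc(C#N)c(Cl)c3)n2)n1`: 1330 nM

Compound 2 sits at one end of these two numbers, separated from compound 1 by a 1.2-fold higher number from compound 1 to compound 2 (0.08 log units; within the scatter). Compound 3 `C[C@@H](Cn1ccc(-c2ccc(C#N)c(Cl)c2)n1)Nc1ncnc2nc[nH]c12` carries a group of 9 heavy atoms (5 carbon, 4 nitrogen; one five-membered aromatic ring with 2 hetero atoms, one six-membered aromatic ring with 2 hetero atoms) in place of a group of 7 heavy atoms (5 carbon, 2 nitrogen; one six-membered aromatic ring with 2 hetero atoms), on an amine nitrogen. Among the compounds with values here, the only measured step that bears on this, an exchange of the heteroaryl on the same amine nitrogen, is a 1.2-fold higher number from compound 1 to compound 2 (0.08 log units; within the scatter), which stayed within the scatter; no step beyond the scatter is therefore expected in this assay either. The expected step is a 1.0-fold lower number from compound 2 to compound 3 (0.01 log units; within the scatter). Compound 3 is estimated at 1300 nM, range 450 nM to 3800 nM.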

Compound 3, half-maximal inhibitory concentration: 960 nM
Compound 3: middle estimate off by 1.4-fold (0.13 log units), on the high side, within the range that was stated.
By their numbers in this assay, from the lowest: compounds 3, 1 and 2 (each within the scatter of the next).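

In this assay, the amine nitrogen also accepts a two-ring group, one five-membered and one six-membered aromatic ring, carrying a hydrogen-bond donor: the change gives a 1.4-fold lower number from compound 2 to compound 3 (0.14 log units; within the scatter) and a 1.2-fold lower number from compound 1 to compound 3 (0.06 log units; within the scatter). Heteroaryl size and ring count at this position have therefore not yet separated the compounds, as the earlier single-ring pair could not show. No available data explain this result. Going by these compounds, whether a non-aromatic group on this nitrogen, such as an acetyl or a piperidine ring, would give a step beyond the scatter remains open.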